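Replacing trifluoromethyl by fluoro on the shared core

The source may hold more compounds than are shown below. What is called first, only, known or untested is meant among the compounds shown, and "the series" means these compounds.

Measured so far in a functional assay on MCF7 cells (Homo sapiens) for antiproliferative activity, read by MTT assay, with a stated time of 72 h; a higher number here means a weaker inhibitor, a lower number a stronger inhibitor:
- compound 1, `COc1ccc(-c2ccc3ncn(-c4cc(OC)c(OC)c(OC)c4)c3c2)cc1F`, gives 520 nM
- compound 2, `COc1cc(-n2cnc3ccc(-c4ccc(C(F)(F)F)cc4)cc32)cc(OC)c1OC`, gives 760 nM
- compound 3, `COc1cc(-n2cnc3ccc(-c4ccc(C)cc4)cc32)cc(OC)c1OC`, gives 110 nM

Of these three, compound 2 has the highest number. Its nearest neighbour is compound 1, reached by a 1.5-fold higher number from compound 1 to compound 2 (0.16 log units; within the scatter), so the two cannot be told apart. The clear gap is to compound 3: a 6.9-fold lower number from compound 2 to compound 3 (0.84 log units; beyond the scatter), a modest change that follows from exchanging one group at the same position on the outer aromatic ring.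

Compound 4, `COc1cc(-n2cnc3ccc(-c4ccc(F)cc4)cc32)cc(OC)c1OC`, is not yet measured. It differs from compound 2 in one place: fluoro in place of trifluoromethyl on an aromatic carbon.

Among the compounds with values here, the step that bears most directly on this is the one from compound 2 to compound 3, where a single group at the same carbon was swapped and the number fell modestly. The step from compound 1 to compound 3 also ended at the lowest number, whereas the step from compound 1 to compound 2 stayed within the scatter. Taking a single small group in place of trifluoromethyl, as in the step to compound 3, the expectation for compound 4 is a lower number than compound 2, probably not quite reaching compound 3.

Compound 4 is therefore estimated at 250 nM, with a likely range from 80 nM to 800 nM, which would mean an expected step of a 3.0-fold lower number from compound 2 to compound 4 (0.48 log units; beyond the scatter).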

Compound 4, half-maximal inhibitory concentration: 1770 nM
Compound 4: middle estimate off by 7.1-fold (0.85 log units), on the low side; the measured number lies above the stated range.
By their numbers in this assay, from the lowest: compound 3; then compounds 1 and 2 (each within the scatter of the next); then compound 4.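

In this assay, taking trifluoromethyl away from this carbon does not push the number in one fixed direction: fluoro gives a 2.3-fold higher number from compound 2 to compound 4 (0.37 log units; beyond the scatter), whereas methyl had given a 6.9-fold lower number from compound 2 to compound 3 (0.84 log units; beyond the scatter). The two replacements therefore lead to opposite results at the same place, and the difference between them is the largest step shown here, a 16-fold higher number from compound 3 to compound 4 (1.21 log units; beyond the scatter), so the outcome depends strongly on which group sits on this carbon, and 4-fluorophenyl also compares poorly with the 3-fluoro-4-methoxyphenyl group, with a 3.4-fold higher number from compound 1 to compound 4 (0.53 log units; beyond the scatter). No accompanying measurement offers an explanation for this reversal.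

The compounds shown leave open where other groups at this carbon would fall relative to methyl and fluoro, for example chloro, ethyl, an amine or a carboxylic acid. They also leave open whether the same order of methyl, trifluoromethyl and fluoro would hold on a different outer ring or in a different cell line, since all of these comparisons rest on single steps around one shared core.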